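From 2H-tetrazol-5-yl to carboxy on a shared core

The source may report more compounds than this note shows. Statements on the series, on what has been measured and on what is new or still open speak of the compounds shown alone.

In a functional assay on the whole organism (stomach) with Rattus norvegicus as the target (a higher number here means that more compound is needed for the effect, a lower number that less compound is needed), compound 1 `O=C(O)c1cc(NC(=O)c2ccc(Cl)cc2)cc(C(=O)O)c1`, with chloro on the shared core, gives 97.3 mg/kg. Compound 2 `CCCCc1ccc(C(=O)Nc2cc(C(=O)O)cc(C(=O)O)c2)cc1`, with butyl in that place, gives 91.9 mg/kg, and the swap brings a 1.1-fold lower number from compound 1 to compound 2 (0.02 log units; within the scatter). Compound 3 `O=C(O)c1cc(NC(=O)c2ccc(-c3nn[nH]n3)cc2)cc(C(=O)O)c1`, with 2H-tetrazol-5-yl there, gives 8.2 mg/kg, the lowest number of the three. It stands clearly apart, with a 12-fold lower number from compound 1 to compound 3 (1.07 log units; beyond the scatter) and an 11-fold lower number from compound 2 to compound 3 (1.05 log units; beyond the scatter).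

Compound 4 `O=C(O)c1ccc(C(=O)Nc2cc(C(=O)O)cc(C(=O)O)c2)cc1` has not yet been measured. It keeps the core of compound 3 but carries carboxy in place of 2H-tetrazol-5-yl on an aromatic carbon, para to a large group: carboxy in place of 2H-tetrazol-5-yl on an aromatic carbon. Within the data shown here, no measured step brings carboxy in or takes it out, so the evidence is indirect. The two large steps show that this place can move the number strongly. Removing 2H-tetrazol-5-yl might undo part of an 11-fold lower number from compound 2 to compound 3 (1.05 log units; beyond the scatter), but carboxy is neither chloro nor butyl, so a full return is not expected. The expected change in this assay is a moderate rise, a 2.4-fold higher number from compound 3 to compound 4 (0.39 log units; beyond the scatter), although a step within the scatter remains possible. For compound 4 the estimated value is 20 mg/kg, with an expected range of 6 mg/kg to 70 mg/kg.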

Compound 4, dose for 50% inhibition: 32.2 mg/kg
The estimate for compound 4 lay 1.6-fold (0.21 log units) below the measured number, and the stated range covers the measured number.
By their numbers in this assay, from the lowest: compound 3; then compound 4; then compounds 2 and 1 (each within the scatter of the next).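

Carboxy is the first group at this place, on an aromatic carbon para to a large group, to land between the earlier extremes in this assay. Giving up 2H-tetrazol-5-yl has a cost (a 3.9-fold higher number from compound 3 to compound 4 (0.59 log units; beyond the scatter)), yet carboxy still holds a clear part of the gain over both earlier groups (a 2.9-fold lower number from compound 2 to compound 4 (0.46 log units; beyond the scatter) and a 3.0-fold lower number from compound 1 to compound 4 (0.48 log units; beyond the scatter)). The position therefore gives graded results rather than a simple on-or-off response, and a five-membered aromatic ring is not needed to bring the number below those of chloro and butyl, although compound 3, which has that ring, stays lowest; no available measurement explains this order.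

These compounds leave open whether the gain needs a group that carries a hydrogen on a heteroatom, as carboxy and 2H-tetrazol-5-yl both do, which a methyl ester or a sulfonic acid at this place could begin to test. They also leave open how an amine or a longer chain ending in carboxy would compare, and whether other five-membered aromatic rings, such as imidazole or triazole, would match 2H-tetrazol-5-yl.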